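A third fluorine at the assay limit

A few compounds are considered here, and "the series" means these few. Any claim that something is new, unique, unknown or untested is made for them only; others in the source may bear on it.

Compound 1 (`C=C[C@@](C)(/C=C/c1ccc(Nc2ccc(F)cc2)cc1)CCC=C(C)C`) was tested in a functional assay on Raji cells (Homo sapiens) for cytotoxicity, with a stated time of 72 h (a lower number here means that less compound is needed, a higher number that more compound is needed for the effect), and gives > 26000 nM, which is a limit of the assay and not a number. Compound 2 (`C=C[C@@](C)(/C=C/c1ccc(Nc2cc(F)cc(F)c2)cc1)CCC=C(C)C`) gives > 26000 nM, also a limit. Both therefore stand at the limit of > 26000 nM in this assay, at which 2 of the 2 values shown sit, so compound 2 has no measured number behind it.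

Compound 3 (`C=C[C@@](C)(/C=C/c1ccc(Nc2cc(F)c(F)cc2F)cc1)CCC=C(C)C`) changes one place of compound 2: 2,4,5-trifluorophenyl in place of 3,5-difluorophenyl on a nitrogen on an aromatic ring.

Among the compounds with values here, the only measured step bearing on this change is a step that the two limits leave unreadable from compound 1 to compound 2. It offers neither a size nor a direction to carry over, so no particular shift is expected in this assay. The expected move is a step that the limit leaves unreadable from compound 2 to compound 3, and it is only a rough estimate. Compound 3 is estimated at 30000 nM, with an expected range from 13000 nM to 60000 nM.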

Compound 3, half-maximal effective concentration: > 26000 nM
Compound 3: a limit, no number; the forecaster's own chance of this, stated with the estimate: 75%; the middle value lies beyond the limit too.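

In this assay compound 3 gives > 26000 nM as a limit of the assay, not a number. No step among compound 1, compound 2 and compound 3 can therefore be read: the limit of > 26000 nM in this assay, at which 3 of the 3 values shown sit.

The compounds shown leave open whether 4-fluorophenyl, 3,5-difluorophenyl and 2,4,5-trifluorophenyl differ at all in this assay once measured below that limit.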